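Compound 2 to compound 4: methoxy in place of iodo

This account rests on a few compounds, and the source may have more. Where it says the series, first, only, none or still open, it means among the compounds named here.

Compound 1 `Cc1nn(-c2ccccc2)c2nc(-c3ccccc3)c(C#N)c(-c3ccccc3O)c12`: > 23000 nM (limit)
Compound 2 `CCc1ccc(-c2nc3c(c(C)nn3-c3ccccc3)c(-c3ccccc3I)c2C#N)cc1`: > 20000 nM (limit)
Compound 3 `CCc1ccc(-c2nc3c(c(C)nn3-c3ccccc3)c(-c3ccccc3Br)c2C#N)cc1`: > 20000 nM (limit)

All three compounds were tested in an ADME assay on BJ cells (Homo sapiens) for cytotoxicity, with a stated time of 72 h (on this read-out lower numbers stand for an effect already at smaller amounts and higher numbers for an effect only at larger amounts of compound), and none of them returned a number. Compound 2 stands at > 20000 nM, which is a limit. Compound 3 gives > 20000 nM, again a limit. Compound 1, which differs from these two in several places, gives > 23000 nM, also a limit. The values shown therefore consist of the limit of > 20000 nM in this assay, at which 2 of the 3 values shown sit, and (the limit of > 23000 nM in this assay, at which 1 of the 3 values shown sits).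

The step in question leads to compound 4 `CCc1ccc(-c2nc3c(c(C)nn3-c3ccccc3)c(-c3ccccc3OC)c2C#N)cc1` and takes 2-iodophenyl to 2-methoxyphenyl (methoxy in place of iodo on an aromatic carbon). This puts methoxy in place of iodo on an aromatic carbon, ortho to a large group.

Within the data shown here, only one measured step bears on this position, a step that the two limits leave unreadable from compound 2 to compound 3, where bromo replaces iodo. It offers no size to carry over and no direction. The expectation therefore rests on compound 2 with its limit of > 20000 nM. The expected change is a number no higher from compound 2 to compound 4 (the limit leaves the size open), which is estimated to stay within the scatter. The assay will most likely report only a limit again. For compound 4 the estimate is 20000 nM, with an expected range from 10000 nM to 30000 nM.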

Compound 4, half-maximal effective concentration: > 20000 nM
Compound 4: no number, only a limit; the forecaster's own chance of this, stated with the estimate: 85%; the middle value sits exactly at the limit.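

In this assay compound 4 gives > 20000 nM, which is a limit. With compound 2 and compound 3 also reported only as limits, neither step to compound 4 can be read. The compounds shown leave open whether iodo, bromo or methoxy at this place makes any difference to the read-out, and where a half-maximal effect would lie.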